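Adding a tetrazolylphenyl group to an inactive amine

The source may hold more compounds than are shown below. What is called first, only, known or untested is meant among the compounds shown, and "the series" means these compounds.

Measured compounds:
- Compound 1, `CN1CCC[C@H](OCc2cc(Cl)cc(Cl)c2)[C@@H]1c1ccccc1`: > 200000 nM
- Compound 2, `O=C(O)c1ccc(CN2CCC[C@H](O[C@H](CO)c3cc(Cl)cc(Cl)c3)[C@@H]2c2ccccc2)cc1`: 11000 nM
- Compound 3, `OC[C@@H](O[C@H]1CCCN(Cc2ccccc2Cc2nnco2)[C@H]1c1ccccc1)c1cc(Cl)cc(Cl)c1`: 3700 nM

All three were tested in an assay on isolated protein for activation of cGMP-dependent protein kinase 1 (Homo sapiens), read by ADP-Glo, with stated times of 120 min and 40 min; a higher number here means that more compound is needed for the effect, a lower number that less compound is needed. For compound 1 the result is a limit rather than a number, (the limit of > 200000 nM in this assay, at which 1 of the 3 values shown sits), so compound 1 stands at the weak end of what the assay can report. Compound 2 and compound 3 both carry a larger aromatic group on the saturated chain carbon bound to the amine nitrogen in the ring, and both also carry a hydroxymethyl on the other side of the core; between them, a 3.0-fold lower number from compound 2 to compound 3 (0.47 log units; beyond the scatter).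

Compound 4, `Clc1cc(Cl)cc(CO[C@H]2CCCN(Cc3ccc(-c4nn[nH]n4)cc3)[C@H]2c2ccccc2)c1`, changes compound 1 at that same carbon: 4-(2H-tetrazol-5-yl)phenyl in place of hydrogen on a saturated chain carbon bound to an amine nitrogen in a ring. Among the compounds with values here, no measured pair isolates exactly this change. The closest point of comparison is compound 2, which carries a carboxyphenyl at that place and gives 11000 nM; compound 4 lacks the hydroxymethyl present in compound 2, so the comparison is indirect. Given that compound 1 sits at the limit, a large drop in the number is expected, an at least 8.0-fold lower number from compound 1 to compound 4 (0.90 log units; beyond the scatter), though its size is uncertain. The estimate for compound 4 is 25000 nM, within 5000 nM to 150000 nM.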

Compound 4, half-maximal effective concentration: 74000 nM
Estimate against measurement, compound 4: 3.0-fold (0.47 log units) below, within the range that was stated.
By their numbers in this assay, from the lowest: compound 3; then compound 2; then compound 4. At a limit, above all of these: compound 1.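

In this assay, 4-(2H-tetrazol-5-yl)phenyl in place of hydrogen on a saturated chain carbon bound to an amine nitrogen in a ring gives an at least 2.7-fold lower number from compound 1 to compound 4 (0.43 log units; beyond the scatter), so on the core of compound 1 this single change alone is enough to bring the result within the range the assay can report as a number. From the compounds shown here alone, the true size of this step stays unknown, and it can only be read as a minimum, as the result for compound 1 is a limit and not a number: the limit of > 200000 nM in this assay, at which 1 of the 4 values shown sits. Compound 4 differs from compound 2 and from compound 3 in more than one place, so their values do not separate the effect of the tetrazole ring from that of the hydroxymethyl.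

The compounds shown leave open how much of the step a plain phenyl would give without the tetrazole ring, and what an amine on that phenyl would do. Also open, going by these compounds, is how the hydroxymethyl would change the number in the presence of 4-(2H-tetrazol-5-yl)phenyl.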